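The source may hold more compounds than are shown below. What is called first, only, known or untested is meant among the compounds shown, and "the series" means these compounds.

Measured compounds in a functional assay on HepG2 cells (Homo sapiens) for inhibition, read by MTT assay, with a stated time of 72 h, tested at 10 uM; on this read-out lower numbers stand for less inhibition of growth and higher numbers for more inhibition of growth at the one concentration tested:
- compound 1 `CC1=C(C(C)CC(=O)OCC(C)COc2no[n+]([O-])c2S(=O)(=O)c2ccccc2)C(=O)c2c(O)cccc2C1=O`: 91.5%
- compound 2 `CC1=C(CCC(=O)OCCOc2no[n+]([O-])c2S(=O)(=O)c2ccccc2)C(=O)c2c(O)cccc2C1=O`: 95.7%
- compound 3 `CC1=C(CCCC(=O)OCCOc2no[n+]([O-])c2S(=O)(=O)c2ccccc2)C(=O)c2c(O)cccc2C1=O`: 95.1%

Compound 1 gives the lowest of the three numbers in this assay, but the gaps to compound 3 and to compound 2 are both within the usual scatter, so the three measured compounds are indistinguishable on this read-out. Among the measured compounds shown here, all three differ from one another in more than one place, so no single-point step among them is available.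

Compound 4 `CC1=C(C(C)CC(=O)OCCCOc2no[n+]([O-])c2S(=O)(=O)c2ccccc2)C(=O)c2c(O)cccc2C1=O` is the next compound of the series and differs from compound 1 in one place: hydrogen in place of methyl on a saturated chain carbon bound to two saturated chain carbons. For the measured compounds named here, no measured pair shows this change on its own. Given that compound 2, which also carries an unbranched linker, sits at 95.7% in this assay, and that compound 3, likewise with an unbranched linker, sits at 95.1%, the change from compound 1 to compound 4 is expected to give no step beyond the scatter, with at most a slight drift upward. For compound 4 the expected value in this assay is 93%, with a range of 85% to 98%; the step from compound 1 that this estimate means is a number 1.5 percentage points higher from compound 1 to compound 4 (within the scatter) and is expected to lie within the scatter.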

Compound 4, percent growth inhibition at one concentration: 92.7%
Compound 4: middle estimate off by 0.3 percentage points, on the high side; the measured number falls inside the stated range.
By their numbers in this assay, from the lowest: compounds 1, 4, 3 and 2 (each within the scatter of the next).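

The change on a saturated chain carbon bound to two saturated chain carbons can now be read on its own: in this assay, hydrogen in place of methyl gives a number 1.2 percentage points higher from compound 1 to compound 4 (within the scatter). At the one concentration tested, this read-out therefore does not separate the methyl compound from the hydrogen compound at this position. No measurement on hand bears on the reason for this result.

Going by these compounds, whether a longer chain or an amine on this carbon would give a step beyond the scatter remains open. Also open, on these data alone, is whether compound 1 and compound 4 would separate at a lower concentration than the single one used here.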